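The compounds below may be only part of what the source reports. "The series", "measured", "known", "first", "only" and "open" are said of these compounds alone.

Measured so far in a functional assay on A549 cells (Homo sapiens) for inhibition, read by MTT assay, with a stated time of 72 h; on this read-out higher numbers stand for weaker inhibition and lower numbers for stronger inhibition:
compound 1 `c1cc(N2CCCCC2)nc(Nc2ccc(Oc3ncnc4sccc34)cc2)n1` — 4020 nM
compound 2 `c1cc(N2CCCC2)nc(Nc2ccc(Oc3ncnc4sccc34)cc2)n1` — 8100 nM
compound 3 `c1ccc2c(c1)CCN(c1ccnc(Nc3ccc(Oc4ncnc5sccc45)cc3)n1)C2` — 6750 nM

On these three numbers compound 3 stands second highest. Its nearest neighbour is compound 2, with a gap of a 1.2-fold lower number from compound 2 to compound 3 (0.08 log units; within the scatter); the wider gap is a 1.7-fold higher number from compound 1 to compound 3 (0.23 log units; within the scatter). All three values sit within the scatter of one another, so no order among them can be claimed.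

Compound 4 `c1ccc2c(c1)CCN2c1ccnc(Nc2ccc(Oc3ncnc4sccc34)cc2)n1` is not yet measured. Its change from compound 3 is 2,3-dihydro-1H-indol-1-yl in place of 1,2,3,4-tetrahydroisoquinolin-2-yl on an aromatic carbon. Within the data shown here, the step that bears on it is the one from compound 1 to compound 2, where pyrrolidin-1-yl replaced piperidin-1-yl, likewise a five-membered non-aromatic ring in place of a six-membered one: a 2.0-fold higher number from compound 1 to compound 2 (0.30 log units; within the scatter). The step from compound 1 to compound 3, a 1.7-fold higher number from compound 1 to compound 3 (0.23 log units; within the scatter), also stayed within the scatter. A comparable shift is therefore expected here, most likely toward a somewhat higher number but not beyond the scatter; the expected step is a 1.3-fold higher number from compound 3 to compound 4 (0.10 log units; within the scatter). Compound 4 is estimated at 8500 nM, with a range from 3500 nM to 20000 nM.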

Compound 4, half-maximal inhibitory concentration: "not active" (no number reported)
The entry for compound 4 holds no number; no gap can be computed for the estimate.
By their numbers in this assay, from the lowest: compounds 1, 3 and 2 (each within the scatter of the next).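

Among these compounds, compound 4 is recorded as "not active" with no number in this assay; no step linking it to compound 3 or to compounds 1 and 2 can be read. Going by these compounds, how far compound 4 lies from those three remains open. No available evidence bears on this result.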